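Swapping the Phenoxy Ring of a Sulfonate Ester

The source may hold more compounds than are shown below. What is called first, only, known or untested is meant among the compounds shown, and "the series" means these compounds.

Compound 1, `CCCN1CCN(c2ccc(S(=O)(=O)Oc3ccc(C)cc3C)cc2)C1=O`, gives 26000 nM.
Compound 2, `CCCN1CCN(c2ccc(S(=O)(=O)Oc3cccc(OC)c3)cc2)C1=O`, gives 25000 nM.

Both compounds were tested in a functional assay on HT-29 cells (Homo sapiens) for antiproliferative activity, read by sulforhodamine B assay, with a stated time of 48 h (on this read-out higher numbers stand for weaker inhibition and lower numbers for stronger inhibition), and compound 2 stands at a value that is indistinguishable from that of compound 1 within the scatter, so neither can be called stronger or weaker. Among the compounds with values here, the only measured step, a 1.0-fold lower number from compound 1 to compound 2 (0.02 log units; within the scatter), changed the ring attached to the sulfonate oxygen without moving the read-out.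

Compound 3, `CCCN1CCN(c2ccc(S(=O)(=O)Oc3ccc(Cl)cc3)cc2)C1=O`, has not yet been measured. It differs from compound 2 in one place: 4-chlorophenyl in place of 3-methoxyphenyl on an oxygen. Within the data shown here, this is the same kind of change as the one measured step, a different ring on the oxygen attached to the sulfonyl sulfur, while the shared core of compound 2 is untouched.

Because the step of a 1.0-fold lower number from compound 1 to compound 2 (0.02 log units; within the scatter) stayed within the scatter, the expectation for compound 3 is a step of no change at the digits printed from compound 2 to compound 3 (within the scatter), which amounts to no change beyond the scatter. Compound 3 is therefore estimated at 25000 nM, with a range from 10000 nM to 60000 nM.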

Compound 3, half-maximal inhibitory concentration: 15000 nM
Beside the measured number, compound 3's estimate is 1.7-fold (0.22 log units) above it, within the range that was stated.
By their numbers in this assay, from the lowest: compounds 3, 2 and 1 (each within the scatter of the next).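

In this assay, a third ring on the oxygen attached to the sulfonyl sulfur gives a 1.7-fold lower number from compound 2 to compound 3 (0.22 log units; within the scatter) and a 1.7-fold lower number from compound 1 to compound 3 (0.24 log units; within the scatter) for the 4-chlorophenyl group. This change takes away the 3-methoxyphenyl group with its one hydrogen-bond acceptor and brings in a chlorine-bearing ring with none, yet the compounds do not separate beyond the scatter, so the three rings shown at this place cannot be told apart by this read-out. No supporting measurement is available to explain how closely these numbers sit.

As far as these compounds go, it remains open whether a phenyl ring carrying a carboxylic acid or an amine, or a butyl chain in place of the ring, would give a number clearly apart from these three. The compounds shown also leave open what happens when the chain on the shared core is altered, as it is identical in compound 1, compound 2 and compound 3.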